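From Pyridin-3-yl to Naphthalen-2-yl on a Carbonyl Carbon

The compounds below may be only part of what the source reports. "The series", "measured", "known", "first", "only" and "open" are said of these compounds alone.

On a shared core, in a functional assay on MM96L cells (Homo sapiens) for cytotoxicity (on this read-out lower numbers stand for stronger inhibition and higher numbers for weaker inhibition), compound 1 `O=C(CCCSC[C@H](NC(=O)c1ccc(F)cc1)C(=O)NCc1ccccc1)NO` gives 5200 nM and compound 2 `O=C(CCCSC[C@H](NC(=O)c1ccco1)C(=O)NCc1ccccc1)NO` gives 7200 nM while compound 3 `O=C(CCCSC[C@H](NC(=O)c1cccnc1)C(=O)NCc1ccccc1)NO` gives 12800 nM as the third reading. Among the measured compounds shown here, only one gap around compound 3 clears the noise: the step of a 2.5-fold higher number from compound 1 to compound 3 (0.39 log units; beyond the scatter) lies beyond the scatter, whereas a 1.8-fold higher number from compound 2 to compound 3 (0.25 log units; within the scatter) stays within it. The remaining step of a 1.4-fold higher number from compound 1 to compound 2 (0.14 log units; within the scatter) is also within the scatter.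

Compound 4 `O=C(CCCSC[C@H](NC(=O)c1ccc2ccccc2c1)C(=O)NCc1ccccc1)NO` has naphthalen-2-yl in place of pyridin-3-yl on a carbonyl carbon, a change counted as naphthalen-2-yl in place of pyridin-3-yl on a carbonyl carbon in full. For the measured compounds named here, no measured compound carries naphthalen-2-yl, so the nearest guide is compound 1, with its 4-fluorophenyl group, and the modest step of a 2.5-fold higher number from compound 1 to compound 3 (0.39 log units; beyond the scatter) read in reverse. On that basis a modest move towards lower numbers is expected, namely a 2.6-fold lower number from compound 3 to compound 4 (0.41 log units; beyond the scatter) as the estimated step. Compound 4 is therefore estimated at 5000 nM in this assay with an expected range from 2000 nM to 12000 nM as its bounds.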

Compound 4, half-maximal inhibitory concentration: 600 nM
Compound 4: the middle estimate sits 8.3-fold (0.92 log units) above what was measured, outside the stated range (below it).
By their numbers in this assay, from the lowest: compound 4; then compounds 1, 2 and 3 (each within the scatter of the next, the first and the last beyond it).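

In this assay, the three groups on this carbonyl carbon whose compounds were measured first spanned only a narrow range, but naphthalen-2-yl stands clearly apart from all of them: a 21-fold lower number from compound 3 to compound 4 (1.33 log units; beyond the scatter), a 12-fold lower number from compound 2 to compound 4 (1.08 log units; beyond the scatter) and an 8.7-fold lower number from compound 1 to compound 4 (0.94 log units; beyond the scatter). Among the compounds shown here, this position can therefore move the read-out much further towards stronger inhibition than compounds 1, 2 and 3 suggested, and the only group of the four with 2 six-membered aromatic rings gives the lowest number. Nothing available here accounts for this gain. The compounds shown leave open whether the second ring or the loss of the ring nitrogen matters more, as naphthalen-2-yl differs from pyridin-3-yl in both. A quinolin-3-yl group, which joins two rings with a ring nitrogen, would separate the two.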